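A few compounds are considered here, and "the series" means these few. Any claim that something is new, unique, unknown or untested is made for them only; others in the source may bear on it.

In a functional assay on DU-145 cells (Homo sapiens) for inhibition, read by trypan blue exclusion, with a stated time of 72 h (on this read-out lower numbers stand for stronger inhibition and higher numbers for weaker inhibition), compound 1 (`Cn1c(=O)c(S(=O)(=O)c2ccc(F)cc2F)cc2cnc(Nc3ccc4occc4c3)nc21`) gives 15000 nM and compound 2 (`Cn1c(=O)c(S(=O)(=O)c2ccc(F)cc2F)cc2cnc(Nc3ccncn3)nc21`) gives 50000 nM on the same core. Among the compounds with values here, the widest measured move is thus a 3.3-fold higher number from compound 1 to compound 2 (0.52 log units; beyond the scatter) and sets the span of the series so far. Compound 3 (`Cn1c(=O)c(S(=O)(=O)c2ccc(F)cc2F)cc2cnc(Nc3ccc4[nH]ncc4c3)nc21`) gives 30000 nM and cannot be separated from either of the other two compounds: the steps are a 2.0-fold higher number from compound 1 to compound 3 (0.30 log units; within the scatter) and a 1.7-fold lower number from compound 2 to compound 3 (0.22 log units; within the scatter) in turn.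

Compound 4 (`Cn1c(=O)c(S(=O)(=O)c2ccc(F)cc2F)cc2cnc(Nc3ccc4c(c3)CC(=O)N4)nc21`) is not yet measured. It differs from compound 3 as follows: a group of 10 heavy atoms (8 carbon, 1 nitrogen, 1 oxygen; one five-membered non-aromatic ring with 1 hetero atom, one six-membered aromatic ring of carbon only) in place of a group of 9 heavy atoms (7 carbon, 2 nitrogen; one five-membered aromatic ring with 2 hetero atoms, one six-membered aromatic ring of carbon only), on a nitrogen on an aromatic ring and keeps the rest of the core unchanged.

All three measured steps change the group at this same place, so all three bear on the new change. Within the data shown here, the closest precedent is a 2.0-fold higher number from compound 1 to compound 3 (0.30 log units; within the scatter) since it also exchanges one two-ring group for another. Compound 2 supplies the only move beyond the scatter, through a 3.3-fold higher number from compound 1 to compound 2 (0.52 log units; beyond the scatter) and that move ends in a group with a single ring, which compound 4 does not carry.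

The estimated step in this assay is no change at the digits printed from compound 3 to compound 4 (within the scatter) and no move beyond the scatter is expected in either direction. For compound 4 the expected value is 30000 nM with an estimated range from 13000 nM to 70000 nM in this assay.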

Compound 4, half-maximal inhibitory concentration: 100000 nM
For compound 4 the middle estimate is 3.3-fold (0.52 log units) below the measured one, outside the stated range (above it).
By their numbers in this assay, from the lowest: compounds 1, 3, 2 and 4 (each within the scatter of the next, the first and the last beyond it).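

Two-ring groups on this nitrogen are not interchangeable in this assay: the group that enters here gives a 3.3-fold higher number from compound 3 to compound 4 (0.52 log units; beyond the scatter) and a 6.7-fold higher number from compound 1 to compound 4 (0.82 log units; beyond the scatter), both beyond the scatter, whereas the earlier exchange of 1-benzofuran-5-yl for 1H-indazol-5-yl stayed within it. A second ring therefore does not by itself keep the number close to that of the 1-benzofuran-5-yl compound, since the step to the two-ring group from the single-ring pyrimidin-4-yl is a 2.0-fold higher number from compound 2 to compound 4 (0.30 log units; within the scatter), within the scatter. No measurement to hand bears on why the number moves with this change.

The entering group differs from 1H-indazol-5-yl in its non-aromatic five-membered ring and in its double bond outside aromatic rings, so these compounds cannot show which of these features goes with the step. Going by these compounds, how a piperidin-4-yl on this nitrogen, or a phenyl carrying a carboxylic acid, would read in this assay remains open, as does whether any group at this place can bring the number clearly under that of the 1-benzofuran-5-yl compound.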